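The source may hold more compounds than are shown below. What is called first, only, known or untested is meant among the compounds shown, and "the series" means these compounds.

The measured compounds:

compound 1, `O=C(NOCc1ccccc1)c1cn(-c2ccccc2)nc1-c1ccccc1`, 13400 nM
compound 2, `O=C(NOCc1ccccc1F)c1cn(-c2ccccc2)nc1-c1ccccc1`, 16100 nM
compound 3, `O=C(NOCc1ccccc1)c1cn(-c2ccccc2)nc1-c1ccc(Cl)cc1`, 10800 nM

All three were tested in a functional assay on MCF7 cells (Homo sapiens) for antiproliferative activity, read by MTT assay, with a stated time of 48 h, in the presence of a further agent that is not named here (on this read-out higher numbers stand for weaker inhibition of growth and lower numbers for stronger inhibition of growth), so each value is the concentration at which growth of the cells is inhibited to the stated degree. Compound 2 is compound 1 with fluoro in place of hydrogen on an aromatic carbon, and that change gave a 1.2-fold higher number from compound 1 to compound 2 (0.08 log units; within the scatter). Compound 3 is compound 1 with a different change, (chloro in place of hydrogen on an aromatic carbon), giving a 1.2-fold lower number from compound 1 to compound 3 (0.09 log units; within the scatter). Compound 4, `O=C(NOCc1ccccc1F)c1cn(-c2ccccc2)nc1-c1ccc(Cl)cc1`, has not been measured yet; it is compound 3 with fluoro in place of hydrogen on an aromatic carbon, the same change that turned compound 1 into compound 2, sitting in the same place. Resting on that earlier step, a 1.2-fold higher number from compound 1 to compound 2 (0.08 log units; within the scatter), the expected step in this assay is a 1.2-fold higher number from compound 3 to compound 4 (0.08 log units; within the scatter). Compound 4 is therefore estimated at 13000 nM. For compound 4 the expected range runs from 6500 nM to 26000 nM.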

Compound 4, concentration for 50% growth inhibition: 15100 nM
Estimate against measurement, compound 4: 1.2-fold (0.07 log units) below; measured number inside the range.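

In this assay, fluoro in place of hydrogen on the benzyl group of compound 3 gives a 1.4-fold higher number from compound 3 to compound 4 (0.15 log units; within the scatter) and matches the earlier step on the other core: the same change on two cores in this assay, a 1.2-fold higher number (0.08 log units; within the scatter) from compound 1 to compound 2 and a 1.4-fold higher number (0.15 log units; within the scatter) from compound 3 to compound 4, 1.2-fold (0.07 log units) apart, within the scatter of two such steps.
Chloro in place of hydrogen gives a 1.1-fold lower number from compound 2 to compound 4 (0.03 log units; within the scatter) and also carries across: the same change on two cores in this assay, a 1.2-fold lower number (0.09 log units; within the scatter) from compound 1 to compound 3 and a 1.1-fold lower number (0.03 log units; within the scatter) from compound 2 to compound 4, 1.2-fold (0.07 log units) apart, within the scatter of two such steps.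
For the compounds shown here, each change therefore behaves alike on these two cores, but every step lies within the scatter, so this shows only that neither change moved growth inhibition measurably here, not that either one helps or harms it, and two cores cannot establish a rule for the series.

As far as these compounds go, it stays open whether larger groups on these rings, such as trifluoromethyl or an amine, would shift the number beyond the scatter. From the compounds shown here alone, a carboxylic acid or a longer chain in place of benzyl is equally open.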